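The compounds below may be only part of what the source reports. "The series", "measured", "known", "first", "only" and "open" are said of these compounds alone.

Measured compounds:

Compound 1 `Fc1ccc(/C=N/c2sc3c(c2-c2nc4ccccc4s2)CCC3)cc1` gives 372 ug/mL in an ADME assay on HeLa cells (Homo sapiens) for cytotoxicity, read by MTT assay, with a stated time of 72 h; a higher number here means that more compound is tolerated, a lower number that less compound is tolerated.
Compound 2 `C(=N/c1sc2c(c1-c1nc3ccccc3s1)CCCC2)\c1ccccc1` gives 333 ug/mL in this assay.

Compound 2 stands with the two numbers shown so far close together: its value in this assay and that of compound 1 differ by an amount that lies within the usual scatter of repeated measurements, so neither can be called better tolerated than the other on these data.

Compound 3 `C(=C/c1ccccc1)\C=N\c1sc2c(c1-c1nc3ccccc3s1)CCCC2` differs from compound 2 in one place: 2-phenylethenyl in place of phenyl on a carbon with a double bond to nitrogen. This keeps the shared core untouched and extends only the group attached to the carbon with a double bond to nitrogen.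

Among the measured compounds shown here, no pair of measured compounds that differ in one place is available to show what such a change does here. With the two measured values so close to each other and the change confined to one group, no step beyond the scatter is expected; the step from compound 2 to compound 3 is estimated at a 1.1-fold lower number from compound 2 to compound 3 (0.05 log units; within the scatter). Compound 3 is therefore expected to give about 300 ug/mL in this assay, with a likely range from 150 ug/mL to 600 ug/mL.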

Compound 3, half-maximal cytotoxic concentration: 389 ug/mL
Compound 3: the middle estimate sits 1.3-fold (0.11 log units) below what was measured; the measured number falls inside the stated range.
By their numbers in this assay, from the lowest: compounds 2, 1 and 3 (each within the scatter of the next).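

Among the compounds shown here, compound 3 gives the first step that can be read at this position, the carbon with a double bond to nitrogen: in this assay, putting 2-phenylethenyl in place of phenyl gives a 1.2-fold higher number from compound 2 to compound 3 (0.07 log units; within the scatter). The larger group, with its extra double bond outside the aromatic ring, therefore leaves compound 2 and compound 3 indistinguishable in this measurement, so this single change gives no sign of altering how much compound the cells tolerate. Nothing available explains this result.

Going by these compounds, both groups in this step carry a six-membered aromatic ring of carbon only, so it remains open whether a group without such a ring, such as an amine or a carboxylic acid, would behave the same way on this carbon. A single step also cannot show whether a longer chain ending in phenyl would stay as close.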